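A 2,3-dichlorophenyl group replaces phenyl in compound 3

A few compounds are considered here, and "the series" means these few. Any claim that something is new, unique, unknown or untested is made for them only; others in the source may bear on it.

In a functional assay on PC-3 cells (Homo sapiens) for cytotoxicity, read by MTT assay, with a stated time of 72 h (a higher number here means a weaker inhibitor, a lower number a stronger inhibitor), compound 3 `CNC(=O)c1cc(Oc2ccc(C(=O)/C=C/c3ccccc3)cc2)ccn1` gives 3170 nM. That value cannot be separated from those of its two measured relatives: compound 1 `CNC(=O)c1cc(Oc2ccc(C(=O)/C=C/c3cccc(Br)c3)cc2)ccn1` gives 3400 nM, and compound 2 `CNC(=O)c1cc(Oc2ccc(C(=O)/C=C/c3ccc(F)cc3Cl)cc2)ccn1` gives 4760 nM. All three sit together within the scatter of this read-out.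

Compound 4 `CNC(=O)c1cc(Oc2ccc(C(=O)/C=C/c3cccc(Cl)c3Cl)cc2)ccn1` differs from compound 3 in one place, 2,3-dichlorophenyl in place of phenyl on a double-bonded chain carbon bound to a double-bonded chain carbon.

Within the data shown here, two measured steps bear on this change, since each connects a halogen-bearing compound with compound 3. Replacing bromo with hydrogen gives a 1.1-fold lower number from compound 1 to compound 3 (0.03 log units; within the scatter). Exchanging the halogenated group of compound 2 for phenyl gives a 1.5-fold lower number from compound 2 to compound 3 (0.18 log units; within the scatter). Neither step leaves the scatter, and among these three compounds, none goes against that picture. None of them carries the 2,3-dichlorophenyl group, however, so the evidence is indirect and the range should stay generous.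

In this assay, no shift beyond the scatter is expected, and the estimated change is a 1.1-fold higher number from compound 3 to compound 4 (0.04 log units; within the scatter). The estimated value for compound 4 is 3500 nM, with an expected range from 1900 nM to 6500 nM.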

Compound 4, half-maximal inhibitory concentration: > 50000 nM
Compound 4 was reported as a limit (the forecaster's own chance of this, stated with the estimate: 3%); middle value at least 14-fold (1.15 log units) away from the limit.
By their numbers in this assay, from the lowest: compounds 3, 1 and 2 (each within the scatter of the next). At a limit, above all of these: compound 4.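

In this assay compound 4 is reported only as a limit, > 50000 nM. The earlier compounds shown here suggested that this position tolerated a change of group, yet it proves sensitive to the change to 2,3-dichlorophenyl: an at least 15-fold higher number from compound 3 to compound 4 (1.19 log units; beyond the scatter), an at least 10-fold higher number from compound 2 to compound 4 (1.02 log units; beyond the scatter) and an at least 14-fold higher number from compound 1 to compound 4 (1.16 log units; beyond the scatter), so compound 4 is weaker than all three. Chloro alone does not bring this shift, as compound 2 also carries chloro on its phenyl and shows a 1.5-fold lower number from compound 2 to compound 3 (0.18 log units; within the scatter), and the true size of all three new steps remains unknown, each resting on one value: the limit of > 50000 nM in this assay, at which 1 of the 4 values shown sits.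

The compounds shown leave open how much weaker compound 4 really is, and whether this result is tied to chloro or would also appear with a 2,3-difluorophenyl or 2,3-dimethylphenyl group at the same place. They also cannot tell whether the sharp drop belongs to 2,3-dichlorophenyl alone or extends to other groups there, such as a naphthyl group.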